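Chloro Added to Compound 1: A Limit Expected Again

This account rests on a few compounds, and the source may have more. Where it says the series, first, only, none or still open, it means among the compounds named here.

Compound 1 `O=C(Nc1cccc(-n2cc(-c3ccncc3)c(-c3ccc(Cl)c(O)c3)n2)c1)Nc1cccc(C(F)(F)F)c1` was tested in a functional assay on SK-OV-3 cells (Homo sapiens) for inhibition, read by sulforhodamine B assay, with a stated time of 48 h; a higher number here means that more compound is tolerated, a lower number that less compound is tolerated. In this assay compound 1 gives > 32500 nM, which is a limit of the assay rather than a number. Compound 2 `O=C(Nc1cccc(-n2cc(-c3ccncc3)c(-c3ccc(Cl)c(O)c3)n2)c1)Nc1cc(C(F)(F)F)cc(C(F)(F)F)c1` carries trifluoromethyl in place of hydrogen on an aromatic carbon compared with compound 1. In this assay compound 2 gives > 50000 nM, again a limit and not a number. The step that the two limits leave unreadable from compound 1 to compound 2 therefore cannot be read in size, as the limit of > 32500 nM in this assay, at which 1 of the 2 values shown sits, and the limit of > 50000 nM in this assay, at which 1 of the 2 values shown sits, together show. Compound 3 `O=C(Nc1cccc(-n2cc(-c3ccncc3)c(-c3ccc(Cl)c(O)c3)n2)c1)Nc1ccc(Cl)c(C(F)(F)F)c1` differs from compound 1 by chloro in place of hydrogen on an aromatic carbon. Going by the values given here, no measured step directly covers this change, and the only measured step, hydrogen to trifluoromethyl on an aromatic carbon, was left unreadable by the two limits. With compound 1 itself sitting at a limit, compound 3 is expected to show no readable step in this assay, and the estimated change a step that the limit leaves unreadable from compound 1 to compound 3 is taken as none beyond the scatter. Compound 3 is therefore estimated at 50000 nM, within a range of 20000 nM to 150000 nM, and most likely reported as a limit.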

Compound 3, concentration lethal to 50% of the cells: > 32500 nM
Compound 3 gave a limit, no number (the forecaster's own chance of this, stated with the estimate: 80%); the middle value does not contradict the limit.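

In this assay compound 3 gives a limit and not a number, as compound 1 does, so the size of the step between compound 1 and compound 3 cannot be read: the limit of > 32500 nM in this assay, at which 2 of the 3 values shown sit.

The compounds shown leave open whether chloro in place of hydrogen on the 3-(trifluoromethyl)phenyl group changes the tolerated concentration at all, and by how much.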